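This account rests on a few compounds, and the source may have more. Where it says the series, first, only, none or still open, it means among the compounds named here.

Measured in an ADME assay on HepG2 cells (Homo sapiens) for cytotoxicity, read by MTT assay, with a stated time of 72 h; on this read-out lower numbers stand for higher toxicity in this test and higher numbers for lower toxicity in this test:
- compound 1 `O=[N+]([O-])c1cnc2c(Br)cc(Cl)cn12`: 16200 nM
- compound 2 `Cc1cc(Br)c2nc(CS(=O)(=O)c3ccccc3)c([N+](=O)[O-])n2c1`: > 31200 nM

The entry for compound 2, > 31200 nM, is a limit. For the measured compounds named here, compound 1, at 16200 nM, therefore holds the only actual number.

Compound 3 `C[S+]([O-])Cc1nc2c(Br)cc(Cl)cn2c1[N+](=O)[O-]` has not yet been measured. It keeps the core of compound 1 and replaces a hydrogen atom with a group on an aromatic carbon, next to the ring atom that bears a nitro group: a group of 4 heavy atoms (2 carbon, 1 oxygen, 1 sulfur; no ring) in place of a hydrogen atom, on an aromatic carbon.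

Going by the values given here, no measured pair shows a change of this kind, so the expectation rests on little. It leans towards a higher number, on the strength of compound 2 and its limit of > 31200 nM. The expected size of a 1.5-fold higher number from compound 1 to compound 3 (0.19 log units; within the scatter) is modest and may not exceed the scatter. For compound 3 the estimated value is 25000 nM, with an expected range of 10000 nM to 60000 nM.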

Compound 3, half-maximal cytotoxic concentration: 51400 nM
Compound 3: the middle estimate sits 2.1-fold (0.31 log units) below what was measured, and the stated range covers the measured number.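

In this assay, a group of 4 heavy atoms in place of a hydrogen atom on this aromatic carbon gives a 3.2-fold higher number from compound 1 to compound 3 (0.50 log units; beyond the scatter), so the position accepts this group with no move towards higher toxicity in this test. For the compounds shown here, this is the first pair that differs in one place, and it gives the position a readable step where compound 1 and compound 2 gave none. Compound 2 also carries a group on this carbon, but its entry is a limit and not a number: the limit of > 31200 nM in this assay, at which 1 of the 3 values shown sits.

As far as these compounds go, whether an amine, a carboxylic acid or a longer chain on the same carbon would give a step of similar size stays open. With a single step, the higher number also cannot be tied to the sulfur atom, the oxygen atom or the carbon atoms of the entering group.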